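Clearance of compound 3 with no direct baseline

The compounds below may be only part of what the source reports. "The series", "measured", "known", "first", "only" and "open" are said of these compounds alone.

Compound 1 `O=C(c1cc(-c2cn[nH]c2)on1)N1CCC(Cc2ccccc2)CC1`: 71.6 mL/min/kg
Compound 2 `O=C(Nc1ccc2[nH]c(=O)oc2c1)C(=O)N1CCN(c2ccccc2)CC1`: "not determined" (no result reported)

In an ADME assay on the whole organism (Rattus norvegicus, strain Sprague-Dawley) for pharmacokinetics, using cassette dosing, at a dose of 0.5 mg/kg by the intravenous route (a lower number here means slower removal, a higher number faster removal of the compound), compound 2 has no single number, and its entry reads "not determined" (no result reported). Compound 3 has the structure `O=C(Nc1ccc2[nH]c(=O)oc2c1)C(=O)N1CCN(c2ccc(C(F)(F)F)cc2)CC1`. The change is trifluoromethyl in place of hydrogen on an aromatic carbon, with trifluoromethyl in place of hydrogen on an aromatic carbon, para to a large group. For the measured compounds named here, no measured step of this kind is available, and compound 2 offers no starting value. A shift beyond the usual scatter in this assay is therefore not expected from this change alone, and no direction can be assigned. Going by the values given here, the only number comes from compound 1 at 71.6 mL/min/kg, a different structure and so only a loose guide. For compound 3, clearance is expected near 45 mL/min/kg, with an estimated range of 18 mL/min/kg to 100 mL/min/kg.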

Compound 3, clearance: 15.1 mL/min/kg
Beside the measured number, compound 3's estimate is 3.0-fold (0.47 log units) above it, and the stated range ends above it.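

For the compounds shown here, compound 2 has no single number in this assay, so no step to compound 3 at 15.1 mL/min/kg can be read. The compounds shown leave open what trifluoromethyl in place of hydrogen does to clearance. No supporting evidence bears on this result.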